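Swapping a Thiazole for an Oxadiazole at the Shared Core

The source may hold more compounds than are shown below. What is called first, only, known or untested is meant among the compounds shown, and "the series" means these compounds.

Measured in an ADME assay on the whole organism (plasma, strain 129/SvEvBrd x C57BL/6) for pharmacokinetics, with Mus musculus as the target, at a dose of 10 mg/kg by the oral route; a higher number here means more compound in the circulation at the dose given, a lower number less compound in the circulation:
compound 1 `OC[C@@H](O)[C@@H](O)[C@H](O)c1c[nH]c(C(F)(F)C(F)(F)F)n1` gives 3060 ng.h/mL
compound 2 `Cc1nc(-c2nc([C@@H](O)[C@H](O)[C@H](O)CO)c[nH]2)cs1` gives 1970 ng.h/mL

In this assay compound 2 (1970 ng.h/mL) stands within the usual scatter of compound 1 (3060 ng.h/mL), so these two numbers set no order between them. The next compound to be tested is compound 3 `OC[C@@H](O)[C@@H](O)[C@H](O)c1c[nH]c(-c2ncon2)n1`, which differs from compound 2 at a single place. It carries 1,2,4-oxadiazol-3-yl in place of 2-methyl-1,3-thiazol-4-yl on an aromatic carbon. Among the compounds with values here, no measured step between two compounds that differ in one place is available as a guide, so only a modest shift is expected, with no change beyond the scatter as the likeliest outcome. The step is estimated as (a 1.3-fold lower number from compound 2 to compound 3 (0.12 log units; within the scatter)). The expected value for compound 3 is (1500 ng.h/mL), with an estimated range from 500 ng.h/mL to 4500 ng.h/mL in this assay ahead of the measurement.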

Compound 3, area under the concentration-time curve: 820 ng.h/mL
Compound 3: middle estimate off by 1.8-fold (0.26 log units), on the high side; the range from low to high includes it.
By their numbers in this assay, from the lowest: compound 3; then compounds 2 and 1 (each within the scatter of the next).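

In this assay, the aromatic carbon between two ring nitrogen atoms turns out to be a place where a change of ring can shift the number beyond the scatter: putting 1,2,4-oxadiazol-3-yl in place of 2-methyl-1,3-thiazol-4-yl gives a 2.4-fold lower number from compound 2 to compound 3 (0.38 log units; beyond the scatter) and is a modest step. Within the data shown here, compounds 1 and 2 alone set no order, so this is the first readable change. Nothing measured here accounts for the drop.

The swap removes the methyl group and changes the ring atoms together, so the compounds shown cannot tell these two changes apart; a methyl-bearing 1,2,4-oxadiazole or an unsubstituted thiazole would separate them. On these data alone, it also remains open how an amine or a carboxylic acid on this carbon would read in the same measurement.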